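A few compounds are considered here, and "the series" means these few. Any claim that something is new, unique, unknown or untested is made for them only; others in the source may bear on it.

Measured so far:
- compound 1 `Cc1onc(NS(=O)(=O)c2cccc3c(N(C)C)cccc23)c1C`: 60 nM
- compound 2 `Cc1noc(NS(=O)(=O)c2cccc3c(NCCCCCc4ccccc4)cccc23)c1C`: 3050 nM
- compound 3 `Cc1noc(NC(=O)c2ccc(N)cc2)c1C`: > 32000 nM (a limit, not a number)

In an assay on VSM-A10 cells for antagonist activity at Endothelin-1 receptor (Rattus norvegicus) (a lower number here means a stronger inhibitor, a higher number a weaker inhibitor), compound 1 gives 60 nM, the lowest of the two numbers obtained in the series. The nearest measured value, that of compound 2 at 3050 nM, lies well beyond the usual scatter of this assay, so compound 1 is clearly the stronger of the two. Compound 3 returns only a limit in this assay, > 32000 nM; this is the limit of > 32000 nM in this assay, at which 1 of the 3 values shown sits, and no number can be read from it.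

Compound 4 `Cc1cnoc1NS(=O)(=O)c1cccc2c(N(C)C)cccc12` has not yet been measured. It differs from compound 1 in one place: 4-methyl-1,2-oxazol-5-yl in place of 4,5-dimethyl-1,2-oxazol-3-yl on a sulfonamide nitrogen, the rest of compound 1 left unchanged. Among the measured compounds shown here, no measured pair isolates this change, since compounds 2 and 3 differ from compound 1 in more than this one place, so their values say nothing direct about it.

The change removes one methyl and shifts the point of attachment of the five-membered ring; the expected step of a 2.5-fold higher number from compound 1 to compound 4 (0.40 log units; beyond the scatter) is a modest loss of potency, at the edge of the scatter, with wide uncertainty. Compound 4 is therefore estimated at 150 nM in this assay, expected between 30 nM and 1000 nM.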

Compound 4, half-maximal inhibitory concentration: 4900 nM
For compound 4 the middle estimate is 33-fold (1.51 log units) below the measured one; measured number above the stated range.
By their numbers in this assay, from the lowest: compound 1; then compounds 2 and 4 (each within the scatter of the next). At a limit, above all of these: compound 3.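

Among the compounds shown here, compound 4 gives the first single-place comparison, and in this assay the change on the sulfonamide nitrogen gives an 82-fold higher number from compound 1 to compound 4 (1.91 log units; beyond the scatter), so the potency of the core of compound 1 depends strongly on which group sits at this position. The two groups share a five-membered aromatic ring with two hetero atoms, the same counts of hydrogen-bond donors and acceptors, and no net charge, so those shared features do not preserve potency here; they differ by one methyl and in the way the ring is attached. Nothing measured in this series bears on why the step is so large.

The step combines the lost methyl with the changed attachment, and the compounds shown do not separate the two, so either could carry most of the loss. Also open, going by these compounds, is how this assay would read other groups on the sulfonamide nitrogen of the same core, such as an unsubstituted phenyl ring, a pyridine ring or a carboxylic acid-bearing ring.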